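Adding a second methyl to compound 3

The compounds below may be only part of what the source reports. "The series", "measured", "known", "first", "only" and "open" are said of these compounds alone.

In a functional assay on HL-60 cells (Homo sapiens) for cytotoxicity, read by WST assay, with a stated time of 48 h (on this read-out lower numbers stand for an effect already at smaller amounts and higher numbers for an effect only at larger amounts of compound), compound 1 `Clc1ccc(C[C@H]2COC[C@@H]2Cc2ccccc2)cc1Cl` gives 19000 nM and compound 2 `Cc1cccc(C[C@H]2COC[C@@H]2Cc2ccc(Cl)c(Cl)c2)c1` gives 28000 nM on the shared core. Compound 3 `Cc1ccc(C[C@H]2COC[C@@H]2Cc2ccc(Cl)c(Cl)c2)cc1` gives 21000 nM and lies within the scatter of both compound 1 and compound 2.

Compound 4 `Cc1ccc(C[C@H]2COC[C@@H]2Cc2ccc(Cl)c(Cl)c2)cc1C` adds one group to compound 3, a methyl in place of hydrogen on an aromatic carbon, ortho to a methyl group: methyl in place of hydrogen on an aromatic carbon.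

Two measured steps are the same kind of replacement: a 1.5-fold higher number from compound 1 to compound 2 (0.17 log units; within the scatter) and a 1.1-fold higher number from compound 1 to compound 3 (0.04 log units; within the scatter) are both within the scatter. Shifting the methyl, a 1.3-fold lower number from compound 2 to compound 3 (0.12 log units; within the scatter) also stays within it. Among the measured compounds shown here, no measured compound carries two methyl groups, so this case is not tested directly. On these small steps, the expected change is a 1.1-fold higher number from compound 3 to compound 4 (0.06 log units; within the scatter) in this assay and no shift beyond the scatter is expected in either direction. For compound 4 the estimated value is 24000 nM with an expected range from 14000 nM to 42000 nM.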

Compound 4, half-maximal effective concentration: 36000 nM
Compound 4: middle estimate off by 1.5-fold (0.18 log units), on the low side; measured number inside the range.
By their numbers in this assay, from the lowest: compounds 1, 3, 2 and 4 (each within the scatter of the next).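

Notes on the methyl position: a second methyl on this ring, on an aromatic carbon ortho to a methyl group, still gives no step beyond the scatter in this assay, with a 1.7-fold higher number from compound 3 to compound 4 (0.23 log units; within the scatter) and a 1.3-fold higher number from compound 2 to compound 4 (0.11 log units; within the scatter). Compound 4 can be reached from either single-methyl compound, and neither route shows a shift that can be told from the scatter. Each route also matches an earlier methyl step on a different core, first for the route from compound 3: the same change on two cores in this assay, a 1.5-fold higher number (0.17 log units; within the scatter) from compound 1 to compound 2 and a 1.7-fold higher number (0.23 log units; within the scatter) from compound 3 to compound 4, 1.2-fold (0.07 log units) apart, within the scatter of two such steps. The route from compound 2 reads the same way: the same change on two cores in this assay, a 1.1-fold higher number (0.04 log units; within the scatter) from compound 1 to compound 3 and a 1.3-fold higher number (0.11 log units; within the scatter) from compound 2 to compound 4, 1.2-fold (0.07 log units) apart, within the scatter of two such steps.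

On this ring the compounds shown carry only hydrogen or methyl. On these data alone, whether a methoxy group, an amine or a carboxylic acid at this aromatic carbon would move the number beyond the scatter remains open.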